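From an octyl amide toward a carboxylic acid

A few compounds are considered here, and "the series" means these few. Any claim that something is new, unique, unknown or untested is made for them only; others in the source may bear on it.

In an assay for inhibition of NAD-dependent protein deacylase sirtuin-6 (Homo sapiens), read by HPLC, with stated times of 15 min and 1 h, tested at 333 uM (on this read-out lower numbers stand for less inhibition and higher numbers for more inhibition at the one concentration tested (going by the name of the read-out)), compound 1 `O=C(CCCSC[C@H](NC(=O)OCc1ccccc1)C(=O)Nc1ccccc1)NCc1ccccc1` gives 30%, while compound 2 `CCCCCCCCNC(=O)CCCSC[C@H](NC(=O)OCc1ccccc1)C(=O)Nc1ccccc1` is recorded as "not active" (no number reported), so no single number describes where compound 2 stands, only that it is reported as not active. Compound 3 `O=C(O)CCCNC(=O)CCCSC[C@H](NC(=O)OCc1ccccc1)C(=O)Nc1ccccc1` has not yet been measured in this assay. It differs from compound 2 by carboxy in place of pentyl on a saturated chain carbon, three bonds along the chain from an amide-type nitrogen. Within the data shown here, compound 2 carries an octyl chain on the amide nitrogen and is reported as not active, and compound 1 with a benzyl group there gives a modest number, so the shared core gives a modest number with the one group and a reported verdict of not active with the other. With a shorter, carboxylic-acid-ended chain, compound 3 is expected to return a small read-out in this assay, around 15%, plausibly between 0% and 40%, with a fair chance that it too is reported as not active.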

Compound 3, a percentage reported as inhibition, at one concentration (the size of the read-out at that concentration, not a potency): 35%
Compound 3: middle estimate off by 20 percentage points, on the low side, within the range that was stated.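

In this assay a chain ending in a carboxylic acid on the amide nitrogen still gives a number: compound 3 gives 35%, whereas compound 2, with its octyl chain, is recorded as "not active" (no number reported), so no step size can be read for that pair. Putting 2-carboxyethyl in place of phenyl on a saturated chain carbon bound to an amide-type nitrogen gives a number 5 percentage points higher from compound 1 to compound 3 (within the scatter), so this read-out does not separate the two groups. Nothing measured here accounts for these results.

Going by these compounds, it remains open how a carboxylic acid on a shorter or longer chain, or an amine at the chain end, would read at this position. On these data alone, each reading comes from a single concentration, so the potency of compound 1 and compound 3 also remains open.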